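A few compounds are considered here, and "the series" means these few. Any claim that something is new, unique, unknown or untested is made for them only; others in the source may bear on it.

Compound 1 `CC1=C(/C=C/C(=O)/C=C/c2ccc(Cl)cc2)C(C)(C)CCC1` sits within a small set of compounds that share one core and differ in the ring at the end of the chain. In a functional assay on Hep cells (Homo sapiens) for cytotoxicity, read by sulforhodamine B assay, with a stated time of 48 h (a higher number here means a weaker inhibitor, a lower number a stronger inhibitor), compound 1 gives 90600 nM, the highest of the two numbers measured there. Its nearest neighbour, compound 2 `COc1ccccc1/C=C/C(=O)/C=C/C1=C(C)CCCC1(C)C`, gives 38900 nM in this assay, a gap beyond the scatter. Compound 3 `CC1=C(/C=C/C(=O)/C=C/c2ccc(Cl)c(Cl)c2)C(C)(C)CCC1` reaches only the assay's limit, > 100000 nM, in this assay. Within the data shown here, the single step measured in one place, an at least 1.1-fold higher number from compound 1 to compound 3 (0.04 log units; that floor lies within the scatter), is bounded by that limit of > 100000 nM in this assay, at which 1 of the 3 values shown sits, and so tells only that the added chloro did not lower the number. Compound 4 `CC1=C(/C=C/C(=O)/C=C/c2cccnc2)C(C)(C)CCC1` differs from compound 1 by pyridin-3-yl in place of 4-chlorophenyl on a double-bonded chain carbon bound to a double-bonded chain carbon. Among the measured compounds shown here, no measured step exchanges the whole ring, so the expectation for compound 4 rests on compound 1 itself and on the small, poorly bounded movement seen from compound 1 to compound 3. The step of a 1.1-fold lower number from compound 1 to compound 4 (0.03 log units; within the scatter) is therefore expected to be small. The estimate for compound 4 in this assay is 85000 nM, within 30000 nM to 250000 nM, with a real chance that only a limit is returned.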

Compound 4, half-maximal inhibitory concentration: 45600 nM
Beside the measured number, compound 4's estimate is 1.9-fold (0.27 log units) above it; measured number inside the range.
By their numbers in this assay, from the lowest: compounds 2, 4 and 1 (each within the scatter of the next, the first and the last beyond it). At a limit, above all of these: compound 3.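

The exchange of the whole ring on a double-bonded chain carbon bound to a double-bonded chain carbon gives a 2.0-fold lower number from compound 1 to compound 4 (0.30 log units; within the scatter) in this assay and so does not separate the two compounds. Pyridin-3-yl, which brings a ring nitrogen and a hydrogen-bond acceptor, and 4-chlorophenyl, which carries a chlorine, therefore read alike here. Unlike the earlier step with the added chloro, this one has a number at both ends, and only compound 3 remains held at a limit: the limit of > 100000 nM in this assay, at which 1 of the 4 values shown sits.

Because the step swaps the chlorine and the ring nitrogen together, it does not tell what either contributes alone. Going by these compounds, whether a ring carrying an amine or a carboxylic acid at this place would move the number beyond the scatter stays open.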